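The compounds below may be only part of what the source reports. "The series", "measured", "known", "first", "only" and "open" are said of these compounds alone.

Series values in a functional assay on HCT-116 cells (Homo sapiens) for antiproliferative activity, read by MTT assay, with a stated time of 48 h; on this read-out higher numbers stand for weaker inhibition and lower numbers for stronger inhibition:
- compound 1 `CCCCCCCCC(CCO)n1cnc2c(OC)ncnc21`: 12800 nM
- compound 2 `CCCCCCCCCCC(CCO)n1cnc2c(OC)ncnc21`: 7530 nM
- compound 3 `CCCCCCCCCCCC(CCO)n1cnc2c(OC)ncnc21`: not yet measured

Within the data shown here, compound 2, at 7530 nM, stands within the scatter of compound 1, the only other measured compound. Compound 3 differs from compound 2 by methyl in place of hydrogen on a saturated chain carbon, ten or more bonds along the chain from an aromatic nitrogen, methyl in place of hydrogen on a saturated chain carbon. Among the measured compounds shown here, the one measured step that bears on this is a 1.7-fold lower number from compound 1 to compound 2 (0.23 log units; within the scatter), a similar change on the same chain. No shift beyond the scatter is therefore expected in this assay. The expected step is a 1.3-fold lower number from compound 2 to compound 3 (0.10 log units; within the scatter). For compound 3 the estimated value is 6000 nM. The expected range for compound 3 runs from 2500 nM to 14000 nM.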

Compound 3, half-maximal inhibitory concentration: 8230 nM
Estimate against measurement, compound 3: 1.4-fold (0.14 log units) below, within the range that was stated.
By their numbers in this assay, from the lowest: compounds 2, 3 and 1 (each within the scatter of the next).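

The added methyl leaves compound 3 within the scatter of compound 2 in this assay (a 1.1-fold higher number from compound 2 to compound 3 (0.04 log units; within the scatter)). The step across the whole series also stays within the scatter (a 1.6-fold lower number from compound 1 to compound 3 (0.19 log units; within the scatter)), so this read-out does not separate the three chain lengths. No measured evidence bears on this result.

On these data alone, whether a longer chain, or an amine or a carboxylic acid in place of the hydroxyl, would give a step beyond the scatter stays open.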